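From 4-ethylphenyl to 4-isopropylphenyl: working notes

A few compounds are considered here, and "the series" means these few. Any claim that something is new, unique, unknown or untested is made for them only; others in the source may bear on it.

Measured in a functional assay on Jurkat cells (Homo sapiens) for inhibition, read by CCK-8 assay, with a stated time of 48 h; on this read-out higher numbers stand for weaker inhibition of growth and lower numbers for stronger inhibition of growth:
compound 1 `Cc1ccc(Nc2nc(Nc3ccc(N4CCN(C)CC4)cn3)ncc2Cl)cc1`: 30900 nM
compound 2 `Cc1cccc(Nc2nc(Nc3ccc(N4CCN(C)CC4)cn3)ncc2Cl)c1`: 15300 nM
compound 3 `CCc1ccc(Nc2nc(Nc3ccc(N4CCN(C)CC4)cn3)ncc2Cl)cc1`: 11100 nM

Compound 3 stands at 11100 nM, level with compound 2 once the scatter is allowed for: a 1.4-fold lower number from compound 2 to compound 3 (0.14 log units; within the scatter). Compound 1 sits clearly higher at 30900 nM.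

Next is compound 4 `CC(C)c1ccc(Nc2nc(Nc3ccc(N4CCN(C)CC4)cn3)ncc2Cl)cc1`, which turns the 4-ethylphenyl of compound 3 into 4-isopropylphenyl: methyl in place of hydrogen on a saturated chain carbon bound to an aromatic carbon and a saturated chain carbon.

The closest measured precedent is the replacement of hydrogen by methyl on a saturated chain carbon bound to an aromatic carbon: a 2.8-fold lower number from compound 1 to compound 3 (0.44 log units; beyond the scatter). The other step, a 2.0-fold lower number from compound 1 to compound 2 (0.31 log units; beyond the scatter), swaps 4-methylphenyl for 3-methylphenyl and bears on this change only weakly. A single precedent is thin support, and nothing measured shows whether the trend continues. A small move in the same direction is therefore expected, smaller than the precedent and possibly lost in the scatter.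

The expected step is a 1.4-fold lower number from compound 3 to compound 4 (0.14 log units; within the scatter).

For compound 4 the estimated value is 8000 nM, with an expected range of 3500 nM to 18000 nM.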

Compound 4, concentration for 50% growth inhibition: 7530 nM
Beside the measured number, compound 4's estimate is 1.1-fold (0.03 log units) above it; low and high end bracket the measured number.
By their numbers in this assay, from the lowest: compounds 4, 3 and 2 (each within the scatter of the next, the first and the last beyond it); then compound 1.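

Working on the 4-substituent of the phenyl ring in this assay, ethyl to isopropyl, that is methyl in place of hydrogen on a saturated chain carbon bound to an aromatic carbon and a saturated chain carbon, gives a 1.5-fold lower number from compound 3 to compound 4 (0.17 log units; within the scatter), so this second added methyl does not show a step beyond the scatter, unlike the earlier 2.8-fold lower number from compound 1 to compound 3 (0.44 log units; beyond the scatter). The isopropyl group does, however, separate compound 4 from both methyl compounds, with a 4.1-fold lower number from compound 1 to compound 4 (0.61 log units; beyond the scatter) and a 2.0-fold lower number from compound 2 to compound 4 (0.31 log units; beyond the scatter), whereas compound 3 separates only from compound 1. Read across compounds 1, 3 and 4, the numbers fall as the group grows from methyl to isopropyl, but only the end points and the first step stand clear of the scatter, and no measurement at hand accounts for this.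

Open, from the compounds shown here alone, is whether a tert-butyl group or a longer chain such as n-butyl in the same place would take the number lower or leave it level. Also open, going by these compounds, is how an amine or a carboxylic acid there would read in this assay, and whether 3-ethylphenyl or 3-isopropylphenyl would track their 4-substituted counterparts.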